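This account rests on a few compounds, and the source may have more. Where it says the series, first, only, none or still open, it means among the compounds named here.

Measured compounds:
compound 1 `CN(C)/N=N/c1ccccc1C(=O)/N=N/C(=O)CC#N` — 2.63
compound 2 `C/N=N/Nc1ccccc1` — 3.6

Of the compounds shown here, two have been measured in a functional assay on L1210 cells (Mus musculus) for antiproliferative activity; a lower number here means a less potent compound, a higher number a more potent compound, by a factor of ten per unit of this negative logarithm. For the measured compounds named here, compound 1 stands as the lower of the two numbers, giving 2.63; the only other number, from compound 2, lies higher by a gap that is beyond the scatter of the method. Going by the values given here, since no step between these two measured compounds is set out, nothing more is said of their pair than what the two values show.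

Compound 3 `CC(=O)/N=N/C(=O)c1ccccc1/N=N/N(C)C` has not yet been measured in this assay. It differs from compound 1 by one change: hydrogen in place of cyano on a saturated chain carbon bound to a carbonyl carbon. No measured pair shows this change, so the size of its effect cannot be read from the shown data. A step of no more than the usual scatter, in either direction, is expected here. Compound 3 is accordingly estimated at 2.7 in this assay, within the range 2.1 to 3.3, which means an expected step of a number 0.07 log units higher from compound 1 to compound 3 (within the scatter).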

Compound 3, logarithm of the reciprocal of the active concentration, log(1/C) in the L1210 assay: 3.05
Estimate against measurement, compound 3: 0.35 log units below, within the range that was stated.
By their numbers in the L1210 assay, from the lowest: compound 1; then compound 3; then compound 2.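

For the compounds shown here, at this place, on a saturated chain carbon bound to a carbonyl carbon, the change from cyano to hydrogen has a readable effect in the L1210 assay: it gives a number 0.42 log units higher from compound 1 to compound 3 (beyond the scatter), a modest step that no earlier compound could show. In a physicochemical assay for lipophilicity (a lower number here means a more polar compound, a higher number a more lipophilic compound), compound 1 gives 1.44 and compound 3 gives 1.49, which amounts to a number 0.05 log units higher from compound 1 to compound 3 (within the scatter), so the step in antiproliferative activity comes without a separation between the two compounds on this scale. No measurement at hand accounts for the step.

The compounds shown do not tell how an amine, a carboxylic acid or a longer chain at this place would stand in the L1210 assay. This single pair also leaves open whether the same change would give a similar step on any other core.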